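The source may report more compounds than this note shows. Statements on the series, on what has been measured and on what is new or still open speak of the compounds shown alone.

Measured compounds:
- compound 1 `O=c1[nH]c(=O)n(COC(CO)CO)cc1O`, in a functional assay on HeLa cells (Homo sapiens) for inhibition, read by MTT assay, with a stated time of 72 h; on this read-out higher numbers stand for weaker inhibition and lower numbers for stronger inhibition: > 100000 nM
- compound 2 `Cn1cc(CO)c(N)nc1=O`, in this assay: > 100000 nM

Compound 1 stands at a limit of the assay rather than at a number: in this assay compound 1 gives > 100000 nM, which is a limit. Compound 2 also gives only a limit, > 100000 nM, in this assay. Nothing more is known about the position of compound 1, because of the limit of > 100000 nM in this assay, at which 2 of the 2 values shown sit.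

Compound 3 `O=C(CCl)Nc1cn(COC(CO)CO)c(=O)[nH]c1=O` is not yet measured. It differs from compound 1 in one place: ((chloromethyl)carbonyl)amino in place of hydroxy on an aromatic carbon. Going by the values given here, no step between measured compounds is available, so the size of the change in this assay can only be guessed from the two limits seen so far. Both measured compounds sit at the same limit, and the account expects that compound 3 most likely stays near it, with a step of a number no higher from compound 1 to compound 3 (the limit leaves the size open) that is expected to be small or none beyond the scatter. The estimate for compound 3 in this assay is 100000 nM, with an expected range from 20000 nM to 300000 nM.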

Compound 3, half-maximal inhibitory concentration: 12000 nM
Compound 3: middle estimate off by 8.3-fold (0.92 log units), on the high side; the measured number lies below the stated range.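

In this assay, the place on the aromatic carbon that holds hydroxy in compound 1 proves open to change: ((chloromethyl)carbonyl)amino in place of hydroxy gives an at least 8.3-fold lower number from compound 1 to compound 3 (0.92 log units; beyond the scatter), which lies beyond the scatter. The earlier compounds shown here could not show this, as both sat at a limit. Compound 3 is the only compound shown with a number, 12000 nM, so the assay can register a change at this place. The full size of the step remains unknown because its starting point is a limit and not a number: the limit of > 100000 nM in this assay, at which 2 of the 3 values shown sit.

With only this one exchange at this place, the compounds shown do not tell whether the chlorine, the carbonyl or the nitrogen of the new group accounts for the step, and a plain amine, an acetylamino group without chlorine or a longer acyl chain on the same carbon would be needed to separate these parts. On these data alone, it also stays open whether the step would hold if the group of 7 heavy atoms, meta to the new group, were replaced by a simple methyl or a longer alkyl chain.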